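Benzyl to Ethyl on the Amine Carbon: Expected Cytotoxicity

A few compounds are considered here, and "the series" means these few. Any claim that something is new, unique, unknown or untested is made for them only; others in the source may bear on it.

Of the compounds shown here, three that share one core have been measured in an ADME assay on HOS cells (Homo sapiens) for cytotoxicity; a lower number here means that less compound is tolerated, a higher number that more compound is tolerated. Compound 1 `CCCN(Cc1cn2c(N3CCN(C)CC3)cccc2n1)[C@H]1CCCc2cccnc21` gives 6700 nM. Compound 2 `CN1CCN(c2cccc3nc(CN(Cc4ccccc4)[C@H]4CCCc5cccnc54)cn23)CC1` gives 9300 nM, the highest of the three numbers. Compound 3 `CNCCN(C)c1cccc2nc(CN(C)[C@H]3CCCc4cccnc43)cn12` gives 2200 nM, and its number lies beyond the scatter below that of compound 2. Among the measured compounds shown here, the only single-point step among the measured compounds is a 1.4-fold higher number from compound 1 to compound 2 (0.14 log units; within the scatter), which stays within the scatter, so compound 1 and compound 2 cannot be told apart on this read-out.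

Compound 4 `CCN(Cc1cn2c(N3CCN(C)CC3)cccc2n1)[C@H]1CCCc2cccnc21` differs from compound 2 by methyl in place of phenyl on a saturated chain carbon bound to an amine nitrogen. For the measured compounds named here, the one measured step that bears on this change is a 1.4-fold higher number from compound 1 to compound 2 (0.14 log units; within the scatter): the same exchange between phenyl and a small alkyl group, made in the opposite direction and with one more chain carbon, and it remained within the scatter. Compound 3 carries a different group on the core and offers no direct guide to this exchange. Compound 4 is therefore expected to show a 1.3-fold lower number from compound 2 to compound 4 (0.12 log units; within the scatter), a step that stays within the scatter. Compound 4 is estimated at 7000 nM, within a range from 3500 nM to 14000 nM.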

Compound 4, half-maximal cytotoxic concentration: 8100 nM
For compound 4 the middle estimate is 1.2-fold (0.06 log units) below the measured one, and the stated range covers the measured number.
By their numbers in this assay, from the lowest: compound 3; then compounds 1, 4 and 2 (each within the scatter of the next).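

In this assay the exchange at this position now has a direct reading, since a 1.1-fold lower number from compound 2 to compound 4 (0.06 log units; within the scatter) stays within the scatter when methyl replaces phenyl on a saturated chain carbon bound to an amine nitrogen. The new compound also isolates chain length among the small alkyl groups: a 1.2-fold higher number from compound 1 to compound 4 (0.08 log units; within the scatter) is the reading for hydrogen in place of methyl on a saturated chain carbon, two bonds along the chain from an amine nitrogen, and it too stays within the scatter. Compounds 1, 2 and 4 therefore cannot be told apart on this read-out, so neither the six-membered aromatic ring of carbon nor the extra chain carbon registers here, and no measurement shown explains this lack of separation.

Compound 3 differs from these three in more than one place, so what separates it from them remains unresolved. From the compounds shown here alone, it also remains open whether a group of another kind on this chain carbon, such as a primary amine, a carboxylic acid or a much longer alkyl chain, would give a step beyond the scatter in this assay.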